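Acetyl in place of 3-chlorobenzoyl on the ring nitrogen

The compounds below may be only part of what the source reports. "The series", "measured", "known", "first", "only" and "open" are said of these compounds alone.

Compound 3 `O=C(Nc1ccccc1C(F)(F)F)C1CCc2ccccc2N1C(=O)c1cccc(Cl)c1` gives 288 nM in a functional assay on MDA-MB-231 cells (Homo sapiens) for cytotoxicity, read by sulforhodamine B assay, with a stated time of 72 h (on this read-out lower numbers stand for stronger inhibition of growth and higher numbers for weaker inhibition of growth), the lowest of the three numbers measured; compound 2 `O=C(Nc1ccccc1C(F)(F)F)C1CCc2ccccc2N1` gives 45500 nM and compound 1 `CC(=O)N1c2ccccc2CCC1C(=O)Nc1ccccc1O` gives 89600 nM. Among the measured compounds shown here, the only single-point step recorded, a 160-fold lower number from compound 2 to compound 3 (2.20 log units; beyond the scatter), shows how much the (3-chlorophenyl)carbonyl group contributes. Compound 4 `CC(=O)N1c2ccccc2CCC1C(=O)Nc1ccccc1C(F)(F)F` differs from compound 3 by methyl in place of 3-chlorophenyl on a carbonyl carbon. For the measured compounds named here, no measured step covers this exchange directly; compound 1, which carries the same acetyl group on a different anilide, sits far up the scale. Most of the gain seen in the step from compound 2 to compound 3 is therefore expected to be lost, and compound 4 is estimated at 20000 nM (range 5000 nM to 80000 nM), a step of a 69-fold higher number from compound 3 to compound 4 (1.84 log units; beyond the scatter).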

Compound 4, concentration for 50% growth inhibition: > 80000 nM
Compound 4 ended at the assay's limit; the forecaster's own chance of this, stated with the estimate: 10%; middle value at least 4.0-fold (0.60 log units) from the limit.
By their numbers in this assay, from the lowest: compound 3; then compounds 2 and 1 (each within the scatter of the next).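

In this assay compound 4 gives > 80000 nM, which is a limit of the assay and not a number. The low number of compound 3 rests on the 3-chlorophenyl and not on the carbonyl alone: methyl in its place gives an at least 270-fold higher number from compound 3 to compound 4 (2.44 log units; beyond the scatter), and acetyl in place of hydrogen on the nitrogen brings no gain, with an at least 1.7-fold higher number from compound 2 to compound 4 (0.24 log units; that floor lies within the scatter). The step from compound 1 to compound 4 cannot be read at this limit.

Still open, as far as these compounds go, is whether plain phenyl, 3-methoxyphenyl or cyclohexyl on this carbonyl carbon keeps the low number. From the compounds shown here alone, a longer chain such as propyl is equally open.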